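Adding a second chloro to the purine-like core of compound 3

A few compounds are considered here, and "the series" means these few. Any claim that something is new, unique, unknown or untested is made for them only; others in the source may bear on it.

Measured compounds:
compound 1 `ClCc1cccc(Cn2cnc3c(Cl)nc(Cl)nc32)c1` — 7240 nM
compound 2 `Nc1nc(Cl)c2ncn(Cc3cccc(CCl)c3)c2n1` — 69200 nM
compound 3 `ClCc1ccc(Cn2cnc3ncnc(Cl)c32)cc1` — 6300 nM

In a functional assay on MDA-MB-231 cells (Homo sapiens) for cytotoxicity, read by sulforhodamine B assay, with a stated time of 48 h (a lower number here means that less compound is tolerated, a higher number that more compound is tolerated), compound 3 gives the lowest of the three numbers, but it sits within the scatter of compound 1, so the two cannot be told apart; only compound 2 stands clearly apart, beyond the scatter. Compound 4 `ClCc1ccc(Cn2cnc3nc(Cl)nc(Cl)c32)cc1` differs from compound 3 at one point (chloro in place of hydrogen on an aromatic carbon); the new group sits between two ring nitrogen atoms of the fused core. Within the data shown here, the single measured step, a 9.6-fold higher number from compound 1 to compound 2 (0.98 log units; beyond the scatter), concerns a different exchange, amino in place of chloro, and does not bear directly on adding a chloro to a carbon that carried hydrogen. Compound 1 carries the same two chloro groups as compound 4 on its core, yet it also differs in where the chloromethyl-bearing arm attaches, so its value and that of compound 3 only show that the two lie close. On that basis the step of a 1.0-fold higher number from compound 3 to compound 4 (0.01 log units; within the scatter) is expected to stay within the scatter. For compound 4 the estimate in this assay is 6500 nM, with a likely range from 3000 nM to 14000 nM.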

Compound 4, concentration lethal to 50% of the cells: 6020 nM
Beside the measured number, compound 4's estimate is 1.1-fold (0.03 log units) above it; measured number inside the range.
By their numbers in this assay, from the lowest: compounds 4, 3 and 1 (each within the scatter of the next); then compound 2.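

In this assay the exchange of hydrogen for chloro on this aromatic carbon, between two ring nitrogen atoms, gives a 1.0-fold lower number from compound 3 to compound 4 (0.02 log units; within the scatter) and so cannot be told apart from no change at all. Among these compounds, this is the first measured pair to isolate this position with this exchange, since the only earlier step, a 9.6-fold higher number from compound 1 to compound 2 (0.98 log units; beyond the scatter) and beyond the scatter, concerned amino in place of chloro. At this position of this compound pair, then, a chloro and a hydrogen read alike. Nothing measured here offers a reason for this result. Still open, from the compounds shown here alone, is how an amino group, a methyl group or a methoxy group at this same position on the core of compound 3 would read, and whether any of them would move the number beyond the scatter.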